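This account rests on a few compounds, and the source may have more. Where it says the series, first, only, none or still open, it means among the compounds named here.

Going by the values given here, in a physicochemical assay for lipophilicity, read by HPLC, measured as octanol-water partition (on this read-out lower numbers stand for lower lipophilicity and higher numbers for higher lipophilicity), compound 1 (`O=C(N/N=C/c1ccc2no[n+]([O-])c2c1)c1ccccc1`) gives 2.2 and stands highest of the two numbers so far. Compound 2 (`NC(=O)c1c(COc2ccc(/C=N/NC(=O)c3ccncc3)cc2)no[n+]1[O-]`) gives 1.3 on the same scale, a gap beyond the usual scatter. Among the compounds with values here, these two compounds do not differ in just one place, so no measured step guides the next comparison. Compound 3 (`O=C(N/N=C/c1ccc2no[n+]([O-])c2c1)c1ccc(O)cc1`) comes from compound 1 through a single change (hydroxy in place of hydrogen on an aromatic carbon) with hydroxy in place of hydrogen on an aromatic carbon, para to a large group, so that phenyl becomes 4-hydroxyphenyl. In this assay a modest downward step is expected, slightly beyond the scatter, and this remains a judgement without a measured pair behind it. The estimated move is a number 0.40 log units lower from compound 1 to compound 3 (beyond the scatter) on this scale. For compound 3 the estimated value is 1.8 with an expected range from 1.3 to 2.2 in this measurement.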

Compound 3, partition coefficient: 1.2
The estimate for compound 3 lay 0.60 log units above the measured number; the measured number lies below the stated range.
By their numbers in this assay, from the lowest: compounds 3 and 2 (each within the scatter of the next); then compound 1.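

The pair of compound 1 and compound 3 isolates a single change, which compound 1 and compound 2 could not do because they differ in more than one place. In this assay, hydroxy in place of hydrogen on an aromatic carbon, para to a large group, turns phenyl into 4-hydroxyphenyl and gives a step of a number 1.00 log units lower from compound 1 to compound 3 (beyond the scatter), so this one added oxygen atom on the shared core is enough to move the read-out clearly. No measurement shown here gives a reason for the size of this step.

A single pair cannot show whether a methoxy group, an amine or a carboxylic acid at this same place would bring a step of similar size. It also leaves open whether hydroxy on another carbon of this ring would behave as it does here.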